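This account rests on a few compounds, and the source may have more. Where it says the series, first, only, none or still open, it means among the compounds named here.

Of the compounds shown here, two have numbers so far in a functional assay on MT4 cells (Homo sapiens) for cytotoxicity, read by CellTiter-Glo, with a stated time of 5 days; a lower number here means that less compound is needed, a higher number that more compound is needed for the effect. Compound 1 (`Cc1ccc(-c2cnoc2)cc1S(=O)(=O)NC1CCCC1`) gives 43200 nM, and compound 2 (`Cc1ccc(-c2cnoc2C)cc1S(=O)(=O)NC1CCCC1`) gives 15100 nM, the lower of the two. Among the compounds with values here, the only measured step, a 2.9-fold lower number from compound 1 to compound 2 (0.46 log units; beyond the scatter), is modest and corresponds to methyl in place of hydrogen on an aromatic carbon.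

Next is compound 3 (`Cc1cc(-c2ccc(C)c(S(=O)(=O)NC3CCCC3)c2)cnn1`), with 6-methylpyridazin-4-yl in place of 5-methyl-1,2-oxazol-4-yl on an aromatic carbon. The change lies on a six-membered aromatic ring of carbon only, meta to a group of 9 heavy atoms and para to a methyl group. The measured step bears on this only loosely, as the series holds no measured replacement of one ring by another.

Within the data shown here, with compound 2 at 15100 nM, the lower of only two values, a modest move toward a higher number in this assay is expected, similar in size to a 2.9-fold lower number from compound 1 to compound 2 (0.46 log units; beyond the scatter). The direction is a weak call. The estimated step is a 2.2-fold higher number from compound 2 to compound 3 (0.34 log units; beyond the scatter). Compound 3 is expected at 33000 nM, with an estimated range of 13000 nM to 80000 nM.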

Compound 3, half-maximal effective concentration: 3760 nM
Estimate against measurement, compound 3: 8.8-fold (0.94 log units) above, outside the stated range (below it).
By their numbers in this assay, from the lowest: compound 3; then compound 2; then compound 1.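

In this assay, the place on the six-membered aromatic ring of carbon only, para to a methyl group and meta to a group of 9 heavy atoms, accepts a six-membered aromatic ring with 2 hetero atoms as well as a five-membered one, and 6-methylpyridazin-4-yl in place of 5-methyl-1,2-oxazol-4-yl gives a 4.0-fold lower number from compound 2 to compound 3 (0.60 log units; beyond the scatter). Within the data shown here, measured against the 1,2-oxazol-4-yl of compound 1, the same group gives an 11-fold lower number from compound 1 to compound 3 (1.06 log units; beyond the scatter), the only large step, so the identity of the ring itself now moves the number, where the earlier pair showed only the effect of a methyl on it. Compounds 2 and 3 have equal counts of hydrogen-bond donors and acceptors and no net charge, and no measurement at hand accounts for the step.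

The compounds shown leave open how the step divides between the ring and its methyl, which a pyridazin-4-yl group without that methyl would help to separate. They also leave open how this place responds to a ring carrying an amine or a carboxylic acid.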